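A few compounds are considered here, and "the series" means these few. Any claim that something is new, unique, unknown or untested is made for them only; others in the source may bear on it.

Three compounds have numbers in hand. Compound 1 `CC(C)(C)n1ncc(OCc2nnc(-c3ccc(Cl)cc3Cl)s2)c(Cl)c1=O`, compound 2 `CCn1ncc(OCc2nnc(-c3ccccc3)o2)c(Cl)c1=O` and compound 3 `CC(C)(C)n1ncc(OCc2nnc(-c3cccc(F)c3)o2)c(Cl)c1=O` share one core and differ in the group on the ring nitrogen and in the aryl ring at the far end. In a functional assay on the whole organism for inhibition, with Mythimna separata as the target, with a stated time of 5 days (on this read-out higher numbers stand for an effect only at larger amounts of compound and lower numbers for an effect already at smaller amounts), compound 1 gives 62.2 ug/mL. Compound 2 gives > 300 ug/mL, which is the limit of > 300 ug/mL in this assay, at which 1 of the 3 values shown sits, rather than a number. Compound 3 gives 7.1 ug/mL, the lowest of the two numbers; the nearest is compound 1, whose number is higher by a gap beyond the scatter.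

Compound 4 `CC(C)(C)n1ncc(OCc2nnc(-c3ccccc3)o2)c(Cl)c1=O` is not yet measured. It differs from compound 3 by hydrogen in place of fluoro on an aromatic carbon. Among the measured compounds shown here, no measured pair shows this change on its own, so the size of the step is open. A small loss is expected, within or just beyond the scatter, given that compound 3 reaches 7.1 ug/mL with the fluoro in place. The expected step of a 2.1-fold higher number from compound 3 to compound 4 (0.32 log units; beyond the scatter) points to a somewhat higher number. Compound 4 is therefore estimated at 15 ug/mL, between 5 ug/mL and 60 ug/mL.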

Compound 4, half-maximal effective concentration: 12.2 ug/mL
Compound 4: middle estimate off by 1.2-fold (0.09 log units), on the high side; the measured number falls inside the stated range.
By their numbers in this assay, from the lowest: compounds 3 and 4 (each within the scatter of the next); then compound 1. At a limit, above all of these: compound 2.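

With hydrogen in place of fluoro on the aromatic carbon, the step in this assay is a 1.7-fold higher number from compound 3 to compound 4 (0.24 log units; within the scatter), so this pair shows that the fluoro is not needed for an effect at this level. Among the compounds shown here, the group on the aromatic nitrogen behaves quite differently: with tert-butyl in place of ethyl, the step is an at least 24-fold lower number from compound 2 to compound 4 (1.39 log units; beyond the scatter), the first view of that change on its own. The true size of this step stays unknown, since it starts from a limit and not a number: the limit of > 300 ug/mL in this assay, at which 1 of the 4 values shown sits.

Still open, going by these compounds, is whether a methoxy or a nitrile in place of the fluoro would also match compound 4. Open too, on these data alone, is what an isopropyl or a cyclopropyl on the aromatic nitrogen would give, as only ethyl and tert-butyl appear there.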